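Furan for Pyridine on a Weakly Binding Analogue

This account rests on a few compounds, and the source may have more. Where it says the series, first, only, none or still open, it means among the compounds named here.

Measured compounds:
compound 1, `Cc1oc(C(=O)O)cc1COc1ccc(-c2ccncc2)cc1`: > 10000 nM
compound 2, `COc1ccc(-c2ccc(OCc3cc(C(=O)NS(=O)(=O)c4ccccc4)oc3C)cc2)c(C)c1`: 21 nM
compound 3, `CC(=O)c1ccc(-c2ccc(OCc3cc(C(=O)NS(=O)(=O)c4ccccc4)oc3C)cc2)cc1`: 20 nM

In an assay on cells for displacement of a labelled ligand from prostaglandin E2 receptor EP4 subtype (Homo sapiens), read by scintillation counting (a lower number here means a stronger inhibitor, a higher number a weaker inhibitor), compound 1 reaches only a limit of the assay, > 10000 nM, and gives no number of its own. For the measured compounds named here, it is the single value that sits at the limit of > 10000 nM in this assay, at which 1 of the 3 values shown sits. Compound 2 and compound 3 differ from compound 1 in more than one place, so neither offers a step from it; in this assay compound 2 gives 21 nM and compound 3 gives 20 nM, and the step between them is a 1.1-fold lower number from compound 2 to compound 3 (0.02 log units; within the scatter). The unmeasured compound 4, `Cc1oc(C(=O)O)cc1COc1ccc(-c2ccoc2)cc1`, differs from compound 1 in one place: furan-3-yl in place of pyridin-4-yl on an aromatic carbon. Going by the values given here, no measured step covers this exchange; the one measured step concerns another part of the shared core and does not bear on it. With nothing to point another way, compound 4 is expected to stay close to compound 1. Compound 4 is therefore estimated at 15000 nM, in a range of 4000 nM to 60000 nM, which is expected to amount to a step that the limit leaves unreadable from compound 1 to compound 4. It is also expected that the assay will most likely again report only a limit for compound 4.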

Compound 4, inhibition constant: > 10000 nM
Compound 4: a limit, no number (the forecaster's own chance of this, stated with the estimate: 70%); the middle value lies beyond the limit too.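

For the compounds shown here, no step from compound 1 to compound 4 can be read, since each gives only a limit and no number in this assay: the limit of > 10000 nM in this assay, at which 2 of the 4 values shown sit. The compounds shown leave open how furan-3-yl and pyridin-4-yl compare on this shared core.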